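A few compounds are considered here, and "the series" means these few. Any claim that something is new, unique, unknown or untested is made for them only; others in the source may bear on it.

Measured so far:
compound 1 `Cc1ccc(N2C(=O)C/C(=C\c3cccc(C(=O)Nc4cccc(F)c4)c3)C2=O)cc1`, in an ADME assay on HCT-116 cells (Homo sapiens) for cytotoxicity, read by MTT assay, with a stated time of 72 h; a higher number here means a weaker inhibitor, a lower number a stronger inhibitor: > 100000 nM
compound 2 `CCCCCN1C(=O)C/C(=C\c2cccc(C(=O)Nc3cccc(CC)c3)c2)C1=O`, in this assay: 75300 nM
compound 3 `CCCCCN1C(=O)C/C(=C\c2cccc(C(=O)NCCCC)c2)C1=O`, in this assay: > 100000 nM

Compound 1 gives only a limit of the assay, not a number. Compound 3 likewise gives only a limit of the assay, and it shares that limit with compound 1, at which two of the three shown values sit (the limit of > 100000 nM in this assay, at which 2 of the 3 values shown sit). Compound 2 is the only one of the three with an actual number, and it is a weak inhibitor of cell growth.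

Compound 4 `CCCCCN1C(=O)C/C(=C\c2cccc(C(=O)Nc3cccc(F)c3)c2)C1=O` has not been measured. It differs from compound 3 in one place: 3-fluorophenyl in place of butyl on an amide-type nitrogen. Going by the values given here, the one measured step that touches this part of the molecule runs the other way: an at least 1.3-fold higher number from compound 2 to compound 3 (0.12 log units; that floor lies within the scatter), where the 3-ethylphenyl group made way for the butyl chain. Here an aromatic ring again replaces the butyl chain, this time a 3-fluorophenyl, and compound 1 carries the same 3-fluorophenyl amide while giving only a limit. Since compound 3 sits at the limit, the step of a number no higher from compound 3 to compound 4 (the limit leaves the size open) is expected to be small, and compound 4 is estimated at 100000 nM, somewhere between 40000 nM and 300000 nM.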

Compound 4, half-maximal inhibitory concentration: > 100000 nM
Compound 4: only a limit was reported; the forecaster's own chance of this, stated with the estimate: 60%; the middle value sits exactly at the limit.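

Compound 4 shows that, with the pentyl group kept on the amide-type nitrogen in a ring, a 3-fluorophenyl on the other amide nitrogen gives only a limit of this assay, so an aromatic ring at this place does not by itself give a readable value: the limit of > 100000 nM in this assay, at which 3 of the 4 values shown sit. Going by these compounds alone, the one readable comparison swaps fluoro for ethyl on an aromatic carbon, and it gives an at least 1.3-fold higher number from compound 2 to compound 4 (0.12 log units; that floor lies within the scatter), so this change cannot be said to separate the two compounds, even though only compound 2 has an actual number. The steps to compound 4 from compound 3 and from compound 1 cannot be read, as each joins two limits.

Going by these compounds, how far any of these limit compounds lies past the top of the tested range stays unknown, and so does any ranking among them. Also open, on these data alone, is whether an amine or a carboxylic acid in place of the fluoro on the aromatic ring, or a longer chain in place of pentyl, would bring a clearly lower number in this assay.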